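A few compounds are considered here, and "the series" means these few. Any claim that something is new, unique, unknown or untested is made for them only; others in the source may bear on it.

Measured so far:
compound 1 `CC(C)[C@@H](C[C@H]1SC(=O)NC1=O)c1ccc(-c2ccc3cccc(F)c3c2)[nH]c1=O` — 17 nM
compound 2 `C/C(=C1/OC(=O)NC1=O)C(c1ccc(-c2ccc3cccc(F)c3c2)[nH]c1=O)C(C)C` — 39 nM
compound 3 `O=C1NC(=O)/C(=C/C2(c3ccc(-c4ccc5cccc(F)c5c4)[nH]c3=O)CC2)O1` — 55 nM

In a functional assay on CHO cells for antagonist activity at prostaglandin E2 receptor EP3 subtype (Homo sapiens), read by cAMP accumulation, with a stated time of 30 min (on this read-out lower numbers stand for stronger inhibition and higher numbers for weaker inhibition), compound 1 stands lowest of the three numbers. The nearest is compound 2, whose number lies beyond the scatter above that of compound 1, and the furthest is compound 3, whose number lies still further beyond the scatter. Compound 1 is thus the most potent of the three measured compounds on this read-out. Within the data shown here, no single-change step between the measured compounds is available, since compound 2 and compound 3 each differ from compound 1 in more than one place.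

The next compound is compound 4 `CC(C)[C@H](C[C@H]1SC(=O)NC1=O)c1ccc(-c2ccc3cccc(F)c3c2)[nH]c1=O`. It differs from compound 1 as follows: the two compounds have the same atoms and bonds and differ only in configuration as drawn: 1 of 2 stereo elements differ; a stereocentre at a saturated chain carbon is drawn R in compound 1 and S in compound 4. Nothing leaves and nothing enters, so the comparison isolates the configuration at the saturated chain carbon alone.

Inversion of a single stereocentre in an otherwise identical pair usually separates the two epimers by a step beyond the scatter, and the measured compound 1 already has the lowest number of the set, so the expected direction for compound 4 is toward a higher number in this assay. The expected step of a 6.5-fold higher number from compound 1 to compound 4 (0.81 log units; beyond the scatter) is a loss of potency beyond the scatter. Compound 4 is estimated at 110 nM, with a range from 25 nM to 600 nM.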

Compound 4, half-maximal inhibitory concentration: 9 nM
Compound 4: middle estimate off by 12-fold (1.09 log units), on the high side, and the stated range ends above it.
By their numbers in this assay, from the lowest: compounds 4 and 1 (each within the scatter of the next); then compounds 2 and 3 (each within the scatter of the next).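

In this assay, inverting the saturated chain carbon gives a 1.9-fold lower number from compound 1 to compound 4 (0.28 log units; within the scatter), so this read-out does not distinguish the R and S configurations drawn at this position. Compound 2 and compound 3 could not address this stereocentre, but the present pair isolates it because a single stereo element is all that changes: the fact that compounds 1 and 4 differ only in the configuration as drawn. Within this pair, either configuration at the saturated chain carbon is compatible with activity in the same range, although this observation extends only to compound 1 and compound 4 and sets no rule for the wider series.

As far as these compounds go, the contribution of the other stereo element remains open, since it is drawn the same way in both compounds and the pair therefore says nothing about its inversion or about the remaining two diastereomers. From the compounds shown here alone, it is also open whether the same indifference to configuration would hold if the group on this carbon were replaced by a longer chain, an amine or a carboxylic acid.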